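Cyclohexyl ring configuration and rat clearance

This account rests on a few compounds, and the source may have more. Where it says the series, first, only, none or still open, it means among the compounds named here.

Three compounds share one core and differ in the group on the ring nitrogen. Compound 1 `CC(C)(O)c1ccc(-c2cnc3c(n2)N(CCC2CCOCC2)C(=O)CN3)cn1` carries a chain ending in a saturated oxygen ring; in an ADME assay on the whole organism for pharmacokinetics, with Rattus norvegicus as the target, at a dose of 2 mg/kg by the intravenous route (on this read-out higher numbers stand for fast clearance and lower numbers for slow clearance), compound 1 gives 9 mL/min/kg. Compound 2 `CO[C@H]1CC[C@@H](CN2CC(=O)Nc3ncc(-c4ccc(C(C)(C)O)nc4)nc32)CC1` carries a methoxy-substituted cyclohexyl ring joined through a methylene, and in this assay compound 2 gives "not determined" (no result reported). Compound 3 `CO[C@H]1CC[C@@H](N2CC(=O)Nc3ncc(-c4ccc(C(C)(C)O)nc4)nc32)CC1` carries the same methoxy-substituted cyclohexyl ring joined directly, and in this assay compound 3 gives "not determined" (no result reported), so no number stands for it; compound 2 likewise has none, and compound 1 alone gives a figure. Compound 4 `CO[C@H]1CC[C@H](N2CC(=O)Nc3ncc(-c4ccc(C(C)(C)O)nc4)nc32)CC1` is the next compound. How compound 4 differs from compound 3: the two compounds have the same atoms and bonds and differ only in configuration as drawn: 2 of 2 stereo elements differ (all stereocentres are inverted: mirror images); a stereocentre at a saturated ring carbon is drawn s in compound 3 and r in compound 4; a stereocentre at a saturated ring carbon is drawn s in compound 3 and r in compound 4. Among the compounds with values here, no measured pair shows what such a change does on this read-out, so a step beyond the scatter in either direction cannot be counted on. Compound 4 is expected to give a figure near that of compound 1, because compound 1 gives 9 mL/min/kg: the estimate is 12 mL/min/kg, within 4 mL/min/kg to 35 mL/min/kg.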

Compound 4, clearance: 1.7 mL/min/kg
Compound 4: middle estimate off by 7.1-fold (0.85 log units), on the high side; measured number below the stated range.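

Compound 3 has no number to set beside compound 4, so no step can be read for this pair, though it is a close one: the fact that compounds 3 and 4 differ only in the configuration as drawn.
The compounds shown leave open whether that inversion of configuration alone shifts the result in this assay, and in which direction.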